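Methyl to ethyl on the ring amine: an expectation

A few compounds are considered here, and "the series" means these few. Any claim that something is new, unique, unknown or untested is made for them only; others in the source may bear on it.

Measured compounds and their values in a functional assay on trachea (Cavia porcellus); a higher number here means a weaker inhibitor, a lower number a stronger inhibitor:
- compound 1, `CCN1CC[C@@]2(OC)OC(N)=C(C#N)[C@@H](c3ccc(Br)cc3)[C@@H]2C1`, compound 1 gives 13200 nM
- compound 2, `CCN1CC[C@@]2(OC)OC(N)=C(C#N)[C@@H](c3ccc(Cl)cc3)[C@@H]2C1`, compound 2 gives 14900 nM
- compound 3, `CO[C@@]12CCN(C)C[C@H]1[C@H](c1ccc(Cl)cc1Cl)C(C#N)=C(N)O2`, compound 3 gives 14900 nM

Compound 3 sits level with compound 2 at the digits shown, and the two together hold the highest numbers of the three; its gap to compound 1 is within the scatter. All three compounds share one core and differ only in the halogens on the aromatic ring and in the group on the ring amine. Among the compounds with values here, the single one-place step, a 1.1-fold higher number from compound 1 to compound 2 (0.05 log units; within the scatter), changes a halogen and lies within the scatter. Compound 4, `CCN1CC[C@@]2(OC)OC(N)=C(C#N)[C@@H](c3ccc(Cl)cc3Cl)[C@@H]2C1`, differs from compound 3 by methyl in place of hydrogen on a saturated chain carbon bound to an amine nitrogen in a ring, read one bond further out as methyl to ethyl. Within the data shown here, no measured step touches that place; compound 2 and compound 3 differ in two places at once, and their values simply sit level. With nothing pointing either way, the expected step of a 1.1-fold lower number from compound 3 to compound 4 (0.03 log units; within the scatter) is none beyond the scatter. Compound 4 is therefore estimated at 14000 nM, expected between 6000 nM and 35000 nM.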

Compound 4, half-maximal inhibitory concentration: 27100 nM
For compound 4 the middle estimate is 1.9-fold (0.29 log units) below the measured one; measured number inside the range.
By their numbers in this assay, from the lowest: compounds 1, 2, 3 and 4 (each within the scatter of the next, the first and the last beyond it).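

In this assay the change from methyl to ethyl on the ring amine now has a measured step of its own (a 1.8-fold higher number from compound 3 to compound 4 (0.26 log units; within the scatter)), so ethyl is accepted at this place with no shift beyond the scatter. Within the data shown here, the added chloro, in place of hydrogen on an aromatic carbon, also stays within the scatter (a 1.8-fold higher number from compound 2 to compound 4 (0.26 log units; within the scatter)), while 2,4-dichlorophenyl in place of 4-bromophenyl gives the only step here beyond it, and a modest one (a 2.1-fold higher number from compound 1 to compound 4 (0.31 log units; beyond the scatter)). Nothing available explains any of these steps.

Among the compounds shown, the methyl to ethyl step rests on a single pair carrying 2,4-dichlorophenyl, so whether it holds with 4-chlorophenyl or 4-bromophenyl stays open. Also open, going by these compounds, is how a longer chain such as propyl, or a benzyl group, on the ring amine would read in this assay.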